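The compounds below may be only part of what the source reports. "The series", "measured", "known", "first", "only" and "open" are said of these compounds alone.

Compound 1, `COc1cc(/C=C/c2nc(N3CCCC3)c3sccc3n2)cc(OC)c1OC`, in a functional assay on L02 cells (Homo sapiens) for inhibition, read by Griess assay, with stated times of 1 h and 24 h (on this read-out higher numbers stand for weaker inhibition and lower numbers for stronger inhibition), gives 681000 nM. For compound 2, `COc1cc(/C=C/c2nc(N3CCN(C)CC3)c3sccc3n2)cc(OC)c1OC`, this assay reports only a limit, > 1000000 nM. Compound 3, `COc1ccc(Nc2nc(/C=C/c3cc(OC)c(OC)c(OC)c3)nc3ccsc23)cc1`, gives 279000 nM in this assay.

Compound 3 stands lowest of the two numbers shown; its nearest neighbour is compound 1, the gap being a 2.4-fold lower number from compound 1 to compound 3 (0.39 log units; beyond the scatter). Against compound 2 the step is an at least 3.5-fold lower number from compound 2 to compound 3 (0.55 log units; beyond the scatter), while an at least 1.4-fold higher number from compound 1 to compound 2 (0.16 log units; that floor lies within the scatter) sits inside the usual variation, a comparison that rests on the limit noted in the limit of > 1000000 nM in this assay, at which 1 of the 3 values shown sits.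

Compound 4, `COc1cc(/C=C/c2nc(NCc3ccc(C)cc3)c3sccc3n2)cc(OC)c1OC`, carries the change (4-methylbenzyl in place of 4-methoxyphenyl on a nitrogen on an aromatic ring). Both measured steps that end at compound 3 swap an entire cyclic amine for the (4-methoxyphenyl)amino group; neither keeps the amino nitrogen and varies only what hangs on it, as the step to compound 4 does. They show that exchanges at this position move the number by modest amounts in either direction, nothing more. The step from compound 3 to compound 4 is therefore expected to stay small, with no clear direction, and the estimate is a 1.3-fold higher number from compound 3 to compound 4 (0.10 log units; within the scatter).

Compound 4 is estimated at 350000 nM in this assay, within a range of 120000 nM to 1000000 nM.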

Compound 4, half-maximal inhibitory concentration: > 1000000 nM
Compound 4: a limit, no number; the forecaster's own chance of this, stated with the estimate: 20%; middle value at least 2.8-fold (0.45 log units) away from the limit.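

In this assay compound 4 gives only a limit, > 1000000 nM. With the amino nitrogen kept and only what hangs on it exchanged, 4-methylbenzyl in place of 4-methoxyphenyl gives an at least 3.5-fold higher number from compound 3 to compound 4 (0.55 log units; beyond the scatter), so at this position the group on that nitrogen is enough by itself to move the number beyond the scatter, something the swaps of whole cyclic amines could not show. Compound 3 now stands lowest against all three other compounds, while the comparison with the pyrrolidin-1-yl compound gives only an at least 1.4-fold higher number from compound 1 to compound 4 (0.16 log units; that floor lies within the scatter), and the step between compound 2 and compound 4 cannot be read, both values being limits.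

Going by these compounds, how far compound 2 and compound 4 really lie from compound 3 stays open: the limit of > 1000000 nM in this assay, at which 2 of the 4 values shown sit. The step to compound 4 also alters the link from the ring to the nitrogen and the group on the ring together, and only a comparison with 4-methylphenyl or 4-methoxybenzyl on the same nitrogen would tell these two parts of the change apart.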